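This account rests on a few compounds, and the source may have more. Where it says the series, first, only, none or still open, it means among the compounds named here.

Measured compounds:
- compound 1, `COc1ccc(N/C=C\C(=O)c2cn(-c3ccccc3)nc2-c2ccc(F)cc2)cc1`: 8900 nM
- compound 2, `COc1ccc(-c2nn(-c3ccccc3)cc2C(=O)/C=C\Nc2ccc(O)cc2)cc1`: 2770 nM

In a functional assay on A549 cells (Homo sapiens) for antiproliferative activity, read by MTT assay, with a stated time of 48 h (a higher number here means a weaker inhibitor, a lower number a stronger inhibitor), compound 2 gives 2770 nM, the lowest of the two numbers in hand. Compound 1 gives 8900 nM in this assay, a gap beyond the scatter, so compound 2 is the stronger of the pair.

Compound 3, `COc1ccc(N/C=C\C(=O)c2cn(-c3ccccc3)nc2-c2ccc(OC)cc2)cc1`, is not yet measured. It differs from compound 2 by methyl in place of hydrogen on an oxygen on an aromatic ring; the change reads as hydroxy to methoxy, (4-hydroxyphenyl)amino to (4-methoxyphenyl)amino.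

Among the measured compounds shown here, no step between two measured compounds isolates this change, so the size of the step is open. Compound 1 also carries a (4-methoxyphenyl)amino and gives the weaker number, which leans the expectation toward a loss. For compound 3 a moderate loss of potency is expected, a 1.6-fold higher number from compound 2 to compound 3 (0.21 log units; within the scatter), with an estimated value of 4500 nM in this assay, within a range of 1800 nM to 12000 nM.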

Compound 3, half-maximal inhibitory concentration: 6780 nM
The estimate for compound 3 lay 1.5-fold (0.18 log units) below the measured number; low and high end bracket the measured number.
By their numbers in this assay, from the lowest: compound 2; then compounds 3 and 1 (each within the scatter of the next).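

In this assay, among the compounds shown here, methyl in place of hydrogen on the oxygen of the (4-hydroxyphenyl)amino group gives a 2.4-fold higher number from compound 2 to compound 3 (0.39 log units; beyond the scatter), so in the one pair that isolates this change, the hydroxy form is the more potent. Methoxy in place of fluoro on an aromatic carbon gives a 1.3-fold lower number from compound 1 to compound 3 (0.12 log units; within the scatter), so this step does not separate those two groups. No measurement in hand offers an explanation for either step.

On these data alone, whether the hydroxy to methoxy step keeps its size with fluoro rather than methoxy on that aromatic carbon remains open. Also open, as far as these compounds go, is how an amine or a carboxylic acid would compare with the hydroxy on the same aromatic ring.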